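The compounds below may be only part of what the source reports. "The series", "measured", "known", "first", "only" and "open" are said of these compounds alone.

Compound 2, with structure `O=C([C@H]1C[C@@H]1F)N1CC2CC(C1)N2`, is the lower of the two compounds measured in an assay on CHO cells for agonist activity at Neuronal acetylcholine receptor; alpha3/alpha6/beta2/beta3 (Homo sapiens), read by FLIPR and calcium flux (a lower number here means a smaller maximal response, a higher number a larger maximal response), where compound 2 gives 85%. Compound 1, with structure `O=C([C@H]1C[C@H]1F)N1CC2CC(C1)N2`, gives 130% in this assay, and the step of a number 45 percentage points lower from compound 1 to compound 2 (beyond the scatter) shows how strongly a single change of configuration on the fluorinated cyclopropane ring can move the maximal response; the only point recorded alongside that step is the fact that one of compounds 1 and 2 is drawn with a defined configuration and the other without, at the place where they differ.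

Compound 3, with structure `O=C([C@@H]1C[C@H]1F)N1CC2CC(C1)N2`, is not yet measured. It differs from compound 2 in this way: the two compounds have the same atoms and bonds; at least one stereo element is drawn with a configuration in one of them and without one in the other: 2 of 4 stereo elements differ; a stereocentre at a saturated ring carbon is drawn R in compound 2 and S in compound 3; a stereocentre at a saturated ring carbon is drawn S in compound 2 and R in compound 3. Within the data shown here, two stereocentres are turned at once, so the measured step from compound 1 to compound 2 bears on it only loosely, and no step between compound 1 and compound 3 is available.

The expected step of a number 20 percentage points higher from compound 2 to compound 3 (beyond the scatter) is therefore uncertain in direction, and compound 3 is estimated at 105%, within a range from 65% to 145% in this assay.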

Compound 3, largest response reached (Emax), in percent of the reference or control that the assay uses: 130%
For compound 3 the middle estimate is 25 percentage points below the measured one, and the stated range covers the measured number.
By their numbers in this assay, from the lowest: compound 2; then compounds 1 and 3 (each within the scatter of the next).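

In this assay, turning both stereocentres on the fluorinated cyclopropane ring gives a number 45 percentage points higher from compound 2 to compound 3 (beyond the scatter), yet turning only one of them gives no change at the digits printed from compound 1 to compound 3 (within the scatter). Among these compounds, the ring carbon that differs between compound 1 and compound 3 can therefore change its configuration here without a visible shift in maximal response, and the large step goes with the other ring carbon, the one that separates compound 1 from compound 2. The record beside these steps gives only the difference in drawn configuration, so it describes the change without explaining it: the fact that one of compounds 2 and 3 is drawn with a defined configuration and the other without, at the place where they differ

Going by these compounds, it remains open whether the first of these ring carbons would stay as silent with the other carbon configured as in compound 2. On these data alone, it is also open whether a chlorine atom or a methyl group in place of the fluorine would show the same dependence on configuration.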